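Compound 3 to compound 4: exchange on the sulfonyl sulfur

The source may hold more compounds than are shown below. What is called first, only, known or untested is meant among the compounds shown, and "the series" means these compounds.

Measured so far in a physicochemical assay for solubility, in phosphate buffer, with a stated time of 24 h, at pH 7.4; a lower number here means a less soluble compound, a higher number a more soluble compound:
compound 1 `Cc1oc(C(=O)NS(=O)(=O)c2ccccc2)cc1COc1ccc(-c2ccccc2)cc1`: 2 ug/mL
compound 2 `CCCS(=O)(=O)NC(=O)c1cc(COc2ccc(-c3ccc(OC)cc3)cc2)c(C)o1`: 7 ug/mL
compound 3 `COc1ccc(-c2ccc(OCc3cc(C(=O)NS(=O)(=O)c4ccc(C)cn4)oc3C)cc2)cc1`: 5 ug/mL

Compound 3 lies within the scatter of compound 2 , and the gap from compound 1 at 2 ug/mL to compound 3 at 5 ug/mL goes beyond the scatter. Compound 1 gives the lowest number of the three.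

Next comes compound 4 `COc1ccc(-c2ccc(OCc3cc(C(=O)NS(=O)(=O)c4ccccc4)oc3C)cc2)cc1`, with this change from compound 3 : phenyl in place of 5-methylpyridin-2-yl on a sulfonyl sulfur. In words, it has phenyl in place of 5-methylpyridin-2-yl on a sulfonyl sulfur.

This exact exchange has not been measured. The nearest evidence with the core of compound 3 held fixed is a 1.4-fold lower number from compound 2 to compound 3 (0.15 log units; within the scatter), with 5-methylpyridin-2-yl in place of propyl on a sulfonyl sulfur. For the measured compounds named here, that step stays within the scatter, so the one measured exchange at this sulfur gives no sign of a large effect in this assay. The core of compound 4 differs from that of compound 1 , though both carry phenyl on the sulfonyl sulfur. The value of compound 1 at 2 ug/mL tilts the expectation slightly downward.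

The expected step is a 1.4-fold lower number from compound 3 to compound 4 (0.15 log units; within the scatter), and no change beyond the scatter is expected. For compound 4 the estimated value is 3.5 ug/mL, with an expected range of 1.5 ug/mL to 8 ug/mL.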

Compound 4, solubility: 11 ug/mL
Beside the measured number, compound 4's estimate is 3.1-fold (0.50 log units) below it, outside the stated range (above it).
By their numbers in this assay, from the lowest: compound 1; then compounds 3, 2 and 4 (each within the scatter of the next, the first and the last beyond it).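

In this assay the sulfonyl sulfur now gives a step beyond the scatter, a 2.2-fold higher number from compound 3 to compound 4 (0.34 log units; beyond the scatter), with phenyl in place of 5-methylpyridin-2-yl, while the two exchanges against propyl stay within it: a 1.4-fold lower number from compound 2 to compound 3 (0.15 log units; within the scatter) and a 1.6-fold higher number from compound 2 to compound 4 (0.20 log units; within the scatter). With phenyl held on the sulfonyl sulfur, methoxy in place of hydrogen on an aromatic carbon gives a 5.5-fold higher number from compound 1 to compound 4 (0.74 log units; beyond the scatter), so a change away from the sulfur also moves the number beyond the scatter. No measurement in hand accounts for the step between 5-methylpyridin-2-yl and phenyl.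

The compounds shown do not separate the ring nitrogen of 5-methylpyridin-2-yl from its methyl group, so an unsubstituted pyridin-2-yl or a methyl-bearing phenyl on the sulfur would be the telling comparison. As far as these compounds go, how an amine or a carboxylic acid on the aromatic ring at this sulfur, or a chain longer than propyl, would read in this assay also stays open.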